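This account rests on a few compounds, and the source may have more. Where it says the series, first, only, none or still open, it means among the compounds named here.

Measured in a functional assay on the whole organism for inhibition, with Rattus norvegicus as the target; a higher number here means that more compound is needed for the effect, a lower number that less compound is needed:
- Compound 1 `CN1CCN(CCN2CCC(c3cn(-c4ccc(F)cc4)c4ccc(Cl)cc34)CC2)C1=O`: 0.021 umol/kg
- Compound 2 `O=C1NCCN1CCCCCN1CCC(c2cn(-c3ccc(F)cc3)c3ccc(Cl)cc23)CC1`: 1.5 umol/kg
- Compound 3 `O=C1NCCN1CCN1CC=C(c2cn(-c3ccc(F)cc3)c3ccc(C(F)(F)F)cc23)CC1`: > 0.66 umol/kg

For compound 3 the value is a limit, not a number. Of the two actual numbers, compound 2 holds the higher at 1.5 umol/kg, and compound 1 stands well apart from it at 0.021 umol/kg.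

Compound 4 `O=C1NCCN1CCCN1CCC(c2cn(-c3ccc(F)cc3)c3ccc(Cl)cc23)CC1` is the next case. It differs from compound 2 by 2-oxoimidazolidin-1-yl in place of 2-(2-oxoimidazolidin-1-yl)ethyl on a saturated chain carbon, three bonds along the chain from an amine nitrogen in a ring. Read one bond further out, 5-(2-oxoimidazolidin-1-yl)pentyl becomes 3-(2-oxoimidazolidin-1-yl)propyl.

Among the measured compounds shown here, one measured step bears on this, the large 71-fold higher number from compound 1 to compound 2 (1.85 log units; beyond the scatter). That step also involves the 3-methyl-2-oxoimidazolidin-1-yl group of compound 1, so only part of it is expected to carry over. The expected change in this assay is therefore a lower number, a 7.5-fold lower number from compound 2 to compound 4 (0.88 log units; beyond the scatter), beyond the scatter but uncertain in size. For compound 4 the estimate is 0.2 umol/kg, with an expected range of 0.03 umol/kg to 1.5 umol/kg.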

Compound 4, dose for half-maximal effect: 1.8 umol/kg
Compound 4: the middle estimate sits 9.0-fold (0.95 log units) below what was measured, and the stated range ends below it.
By their numbers in this assay, from the lowest: compound 1; then compounds 2 and 4 (each within the scatter of the next).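

Within this series, the 5-(2-oxoimidazolidin-1-yl)pentyl and 3-(2-oxoimidazolidin-1-yl)propyl chains cannot be told apart in this assay (a 1.2-fold higher number from compound 2 to compound 4 (0.08 log units; within the scatter)), so this change in chain length at this position has no readable effect on the number. The gap to the 3-methyl-2-oxoimidazolidin-1-yl group remains large with the shorter chain as well (an 86-fold higher number from compound 1 to compound 4 (1.93 log units; beyond the scatter)), so the two chain lengths of the unmethylated ring share the same distance from compound 1. Nothing measured here gives a cause for either result.

Still open, as far as these compounds go, is how much of the gap to compound 1 belongs to the methyl group on the ring and how much to the 2-carbon chain, since the two differ together in these steps. An ethyl group in place of that methyl, or a 2-oxoimidazolidin-1-yl ring carrying an acetyl group, would test how much that ring substituent matters.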